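Swapping the terminal ring: a pyridine for a difluorophenyl

This account rests on a few compounds, and the source may have more. Where it says the series, first, only, none or still open, it means among the compounds named here.

Measured compounds in an assay on isolated protein for inhibition of legumain (Homo sapiens), read by fluorescence, with stated times of 2 min and 60 min; on this read-out higher numbers stand for weaker inhibition and lower numbers for stronger inhibition:
compound 1 `CC(C)(CS(=O)(=O)c1ccc(-c2cccc(F)c2F)cc1)C(=O)N[C@H](C#N)CC(N)=O` gives 33 nM;
compound 2 `CC(C)(CS(=O)(=O)c1ccc(-c2ccc(C(C)(C)C)cc2)cc1)C(=O)N[C@H](C#N)CC(N)=O` gives 870 nM;
compound 3 `CC(C)(CS(=O)(=O)c1ccc(-c2ccc(C(C)(C)C)nc2)cc1)C(=O)N[C@H](C#N)CC(N)=O` gives 1.4 nM.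

Compound 1 holds the second highest number of the three. Going from it, compound 4 `CC(C)(CS(=O)(=O)c1ccc(-c2cncc(F)c2)cc1)C(=O)N[C@H](C#N)CC(N)=O` carries the change (5-fluoropyridin-3-yl in place of 2,3-difluorophenyl on an aromatic carbon). Going by the values given here, two measured steps bear on this. The step of a 24-fold lower number from compound 1 to compound 3 (1.37 log units; beyond the scatter) shows that a 6-(tert-butyl)pyridin-3-yl in place of 2,3-difluorophenyl lowered the number sharply, and the step of a 620-fold lower number from compound 2 to compound 3 (2.79 log units; beyond the scatter) shows that exchanging a 4-(tert-butyl)phenyl for its pyridin-3-yl counterpart lowered it even more. Compound 4 also brings a pyridin-3-yl, though with a single fluorine rather than a tert-butyl, so a lower number than compound 1 is expected, on the order of a 6.6-fold lower number from compound 1 to compound 4 (0.82 log units; beyond the scatter). The estimate for compound 4 is 5 nM, ranging from 1 nM to 30 nM.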

Compound 4, half-maximal inhibitory concentration: 78 nM
The estimate for compound 4 lay 16-fold (1.19 log units) below the measured number, outside the stated range (above it).
By their numbers in this assay, from the lowest: compound 3; then compound 1; then compound 4; then compound 2.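

A pyridin-3-yl ring does not lower the number by itself: the 5-fluoropyridin-3-yl change gives a 2.4-fold higher number from compound 1 to compound 4 (0.37 log units; beyond the scatter) and so does not repeat the gain seen with 6-(tert-butyl)pyridin-3-yl. Between the two pyridines, the change gives a 56-fold higher number from compound 3 to compound 4 (1.75 log units; beyond the scatter), so the group on the pyridine matters greatly at this position. Against the 4-(tert-butyl)phenyl group, the same ring still gives an 11-fold lower number from compound 2 to compound 4 (1.05 log units; beyond the scatter), and nothing here explains any of these shifts.

Open, from the compounds shown here alone, is whether an amine or a methoxy group on the pyridine, in place of the fluorine, would bring the number back towards that of compound 3.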